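Compound 3 to compound 4: expected change in solubility

This account rests on a few compounds, and the source may have more. Where it says the series, first, only, none or still open, it means among the compounds named here.

Measured so far in a physicochemical assay for solubility, measured as kinetic solubility (a lower number here means a less soluble compound, a higher number a more soluble compound), for the series:
- compound 1 `Cc1cnc(NC(=O)c2cc(Oc3ccc(C(=O)N(C)C)nc3)c3cc(C)oc3c2)cn1` gives 418000 nM
- compound 2 `Cc1cnc(NC(=O)c2cc(Oc3cnc(C(=O)N4CCC4)cn3)c3cc(C)oc3c2)cn1` gives 10000 nM
- compound 3 `Cc1ccc(NC(=O)c2cc(Oc3cnc(C(=O)N(C)C)cn3)c3cc(C)oc3c2)nc1` gives 215000 nM

Compound 3 and compound 1 lie within the scatter of each other. Compound 2 lies beyond the scatter from compound 3, on the lower side.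

For the measured compounds named here, the next structure is compound 4 `Cc1cc2c(Oc3cnc(C(=O)N(C)C)cn3)cc(C(=O)Nc3cnc(C(F)(F)F)cn3)cc2o1` with 5-(trifluoromethyl)pyrazin-2-yl in place of 5-methylpyridin-2-yl on an amide-type nitrogen as its only difference from compound 3. Going by the values given here, no measured pair differs in one place only, so the data do not test this change directly. The expectation is therefore loose. A fall beyond the scatter in this assay is expected, and compound 2 at 10000 nM shows that the series can reach much lower numbers. The estimated move is a 7.2-fold lower number from compound 3 to compound 4 (0.86 log units; beyond the scatter) in the downward direction. For compound 4 the estimated value is 30000 nM with an expected range from 5000 nM to 150000 nM around it.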

Compound 4, solubility: 6000 nM
The estimate for compound 4 lay 5.0-fold (0.70 log units) above the measured number, and the stated range covers the measured number.
By their numbers in this assay, from the lowest: compounds 4 and 2 (each within the scatter of the next); then compounds 3 and 1 (each within the scatter of the next).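

In this assay, the series now has its first step that differs in one place only: 5-(trifluoromethyl)pyrazin-2-yl in place of 5-methylpyridin-2-yl on the amide-type nitrogen gives a 36-fold lower number from compound 3 to compound 4 (1.55 log units; beyond the scatter). For the compounds shown here, the group on this nitrogen can therefore move the read-out well beyond the scatter with the rest of the structure unchanged, which the earlier compounds, each differing in more than one place, could not show. No supporting measurement bears on this step.

Going by these compounds alone, the single step does not separate the exchange of methyl for trifluoromethyl from the added ring nitrogen, and 5-(trifluoromethyl)pyridin-2-yl on the same nitrogen would divide the two. Also open, from the compounds shown here alone, is how the read-out responds when a primary amine or a carboxylic acid stands in place of the trifluoromethyl.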